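Compound 1 and the step to compound 3

The source may hold more compounds than are shown below. What is called first, only, known or untested is meant among the compounds shown, and "the series" means these compounds.

Measured in an ADME assay on HEL cells (Homo sapiens) for cytotoxicity; a higher number here means that more compound is tolerated, a lower number that less compound is tolerated:
Compound 1 `C/C(=N\NC(=O)COc1cccc2ccccc12)c1cccc([N+](=O)[O-])c1`: 10.5 ug/mL
Compound 2 `COc1cc(/C=N/NC(=O)COc2cccc3ccccc23)cc(OC)c1OC`: 47.9 ug/mL

Of these two, compound 1 stands lowest at 10.5 ug/mL, and compound 2 gives 47.9 ug/mL. The gap between the two lies beyond the scatter. The two differ in more than one place, so no measured single change is available as a guide. Compound 3 `C/C(=N\NC(=O)COc1cccc2ccccc12)c1ccccc1O` has not yet been measured. It carries 2-hydroxyphenyl in place of 3-nitrophenyl on a carbon with a double bond to nitrogen. With so few data, only a modest rise in this assay is expected, about the size of the scatter, since compound 1 sits at the lower end with 10.5 ug/mL. The estimated change is a 1.9-fold higher number from compound 1 to compound 3 (0.28 log units; within the scatter). For compound 3 the expected value is 20 ug/mL, within an estimated range of 6 ug/mL to 70 ug/mL.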

Compound 3, half-maximal cytotoxic concentration: 4 ug/mL
The estimate for compound 3 lay 5.0-fold (0.70 log units) above the measured number; measured number outside the range, below it.
By their numbers in this assay, from the lowest: compound 3; then compound 1; then compound 2.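

In this assay the place on a carbon with a double bond to nitrogen proves sensitive to the group it carries: 2-hydroxyphenyl in place of 3-nitrophenyl gives a 2.6-fold lower number from compound 1 to compound 3 (0.42 log units; beyond the scatter) and this modest step lies beyond the scatter. Within the data shown here, this is the first single change that can be read, and it shows that less compound is tolerated with 2-hydroxyphenyl at this place than with 3-nitrophenyl. No measurement at hand bears on why the number falls with this exchange.

A single step replaces one substituted ring with another, so it cannot separate the departure of the nitro group from the arrival of the hydroxyl group. As far as these compounds go, whether an amine or a carboxylic acid on the same ring would move the number in the same direction also remains open.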